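Moving the hydroxy group around the ring

A few compounds are considered here, and "the series" means these few. Any claim that something is new, unique, unknown or untested is made for them only; others in the source may bear on it.

Of the compounds shown here, two built on a shared core have been tested in a functional assay on HCT-116 cells (Homo sapiens) for cytotoxicity, read by MTT assay, with a stated time of 48 h; a higher number here means a weaker inhibitor, a lower number a stronger inhibitor. Compound 1 `O=C(/C=C/c1ccc2c(c1)B(O)OC2)c1ccc(Br)cc1` gives 9900 nM, and compound 2 `O=C(/C=C/c1ccc2c(c1)B(O)OC2)c1ccc(O)cc1` gives 24100 nM. Going by the values given here, the step of a 2.4-fold higher number from compound 1 to compound 2 (0.39 log units; beyond the scatter) is the only measured change so far, and it leaves compound 2 with the higher of the two numbers, making it the weaker inhibitor of the pair. Compound 3 `O=C(/C=C/c1ccc2c(c1)B(O)OC2)c1cccc(O)c1` differs from compound 2 in one place: 3-hydroxyphenyl in place of 4-hydroxyphenyl on a carbonyl carbon. Among the compounds with values here, no measured step moves a group to a different position on a ring in this way; the single step available swaps one group for another at a fixed spot, so it gives no guide to the size or direction of this change. The expected step is therefore none beyond the scatter, a 1.0-fold lower number from compound 2 to compound 3 (0.00 log units; within the scatter). Compound 3 is estimated at 24000 nM, with a range from 10000 nM to 55000 nM.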

Compound 3, half-maximal inhibitory concentration: 6500 nM
For compound 3 the middle estimate is 3.7-fold (0.57 log units) above the measured one; measured number below the stated range.
By their numbers in this assay, from the lowest: compounds 3 and 1 (each within the scatter of the next); then compound 2.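

In this assay, the earlier pair showed only what swapping one group for another at a fixed spot can do. This result shows that the place of the hydroxy group on the ring matters in its own right, with a 3.7-fold lower number from compound 2 to compound 3 (0.57 log units; beyond the scatter) even though 3-hydroxyphenyl and 4-hydroxyphenyl hold the same atoms. The comparison with the bromo compound gives a 1.5-fold lower number from compound 1 to compound 3 (0.18 log units; within the scatter) so a hydroxy group on this ring does not always go with the weaker number seen for compound 2, and no evidence is available to explain the effect of moving it.

Still open, from the compounds shown here alone, is whether moving the bromo group around the ring would change the number in the same way as moving the hydroxy group. It is also unknown what an amine or a carboxylic acid would give in place of the hydroxy group of 3-hydroxyphenyl.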